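Swapping the Chloroethyl Group for Propylamino on the Carbonyl

This account rests on a few compounds, and the source may have more. Where it says the series, first, only, none or still open, it means among the compounds named here.

For the measured compounds named here, compound 2 `CC(C)c1ccccc1OS(=O)(=O)c1ccc(NC(=O)CCCl)cc1` stands at the top of the two numbers measured so far: in a functional assay on HT-29 cells (Homo sapiens) for antiproliferative activity, read by sulforhodamine B assay, with a stated time of 48 h (on this read-out lower numbers stand for stronger inhibition and higher numbers for weaker inhibition), compound 2 gives 16000 nM. Its nearest neighbour, compound 1 `CCCC(=O)Nc1ccc(S(=O)(=O)Oc2ccccc2C(C)C)cc1`, sits lower, and in this assay compound 1 gives 4900 nM. Going by the values given here, the single step in hand, a 3.3-fold higher number from compound 1 to compound 2 (0.51 log units; beyond the scatter), consisted of chloro in place of methyl on a saturated chain carbon, two bonds along the chain from a carbonyl carbon. Compound 3 `CCCNC(=O)Nc1ccc(S(=O)(=O)Oc2ccccc2C(C)C)cc1` is the next candidate. Its difference from compound 2 is propylamino in place of 2-chloroethyl on a carbonyl carbon whose other neighbours are an amide-type nitrogen. Among the compounds with values here, no measured step bears directly on this exchange; the only step known concerns the chlorine, and compound 3 carries none, so compound 3 resembles compound 1 more than compound 2 in that respect. The step expected is a 2.7-fold lower number from compound 2 to compound 3 (0.43 log units; beyond the scatter). Compound 3 is therefore estimated at 6000 nM in this assay, with a range from 1500 nM to 25000 nM.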

Compound 3, half-maximal inhibitory concentration: 6300 nM
Estimate against measurement, compound 3: 1.1-fold (0.02 log units) below; the measured number falls inside the stated range.
By their numbers in this assay, from the lowest: compounds 1 and 3 (each within the scatter of the next); then compound 2.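

Putting propylamino in place of 2-chloroethyl on the carbonyl carbon brings the number in this assay down, with a 2.5-fold lower number from compound 2 to compound 3 (0.40 log units; beyond the scatter), so the change at this position registers when the group that leaves is the chlorine-bearing chain. The comparison with the propyl group adds something the first two compounds could not show: a 1.3-fold higher number from compound 1 to compound 3 (0.11 log units; within the scatter), so in this assay propylamino and propyl on the carbonyl carbon cannot be told apart, and a nitrogen at this point of the chain leaves the number unchanged within the usual scatter. Of the three compounds, only compound 2 stands apart from the other two, but no accompanying measurement explains why the numbers fall this way.

On these data alone, it remains open whether the higher number of compound 2 is specific to chlorine or would also appear with fluoro, bromo or hydroxyl at the end of that chain. Also open, as far as these compounds go, is whether a longer chain, a cyclic amine such as piperidine or a carboxylic acid on the carbonyl carbon would move the number beyond the scatter, in either direction, on the same shared core.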